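A few compounds are considered here, and "the series" means these few. Any claim that something is new, unique, unknown or untested is made for them only; others in the source may bear on it.

Measured so far:
compound 1 `Nc1cccc(-c2cn3nc(-c4cccs4)sc3n2)c1` — > 250000 nM
compound 2 `C=C(Br)C(=O)Nc1cccc(-c2cn3nc(Cc4cccc(OC)c4)sc3n2)c1` — 3100 nM
compound 3 `COc1ccc(-c2nn3cc(-c4cccc(N)c4)nc3s2)cc1OC` — 14000 nM

In a functional assay on CCRF-CEM cells (Homo sapiens) for inhibition, read by cell counting, with a stated time of 3 days (on this read-out lower numbers stand for stronger inhibition and higher numbers for weaker inhibition), compound 1 sits at a limit of the assay, > 250000 nM, and no number is known for it (the limit of > 250000 nM in this assay, at which 1 of the 3 values shown sits). Of the two numbers in this assay, compound 2 gives the lower, 3100 nM; compound 3 gives 14000 nM, a gap beyond the scatter.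

Compound 4 `C=C(Br)C(=O)Nc1cccc(-c2cn3nc(-c4cccc(OC)c4)sc3n2)c1` is not yet measured. It differs from compound 2 in one place: 3-methoxyphenyl in place of 3-methoxybenzyl on an aromatic carbon. For the measured compounds named here, no measured pair shows this step. Compound 3 carries an aryl group at that carbon and a number in the range of compound 2, so no change beyond the scatter is expected.

Compound 4 is expected to give 4000 nM in this assay, within 1000 nM to 16000 nM, an estimated step of a 1.3-fold higher number from compound 2 to compound 4 (0.11 log units; within the scatter).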

Compound 4, half-maximal inhibitory concentration: 1200 nM
Beside the measured number, compound 4's estimate is 3.3-fold (0.52 log units) above it, and the stated range covers the measured number.
By their numbers in this assay, from the lowest: compound 4; then compound 2; then compound 3. At a limit, above all of these: compound 1.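

In this assay, 3-methoxyphenyl in place of 3-methoxybenzyl on this aromatic carbon gives a 2.6-fold lower number from compound 2 to compound 4 (0.41 log units; beyond the scatter), the only one-place comparison shown at this position. Inhibition does not depend on the benzyl link carbon here: the aryl ring set directly on the shared core gives a modest gain. Nothing measured here gives a cause for this step.

Still open, going by these compounds, is whether a longer chain at this carbon, such as 2-phenylethyl, would reverse the direction of the step. On these data alone, the effect of a carboxylic acid in place of the methoxy group on the aryl ring is also open.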